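The source may hold more compounds than are shown below. What is called first, only, known or untested is meant among the compounds shown, and "the series" means these compounds.

In an ADME assay on NIH3T3 cells (Mus musculus) for cytotoxicity, read by XTT assay, with a stated time of 24 h (on this read-out lower numbers stand for stronger inhibition and higher numbers for weaker inhibition), compound 2 `Cc1ccc(-c2csc(N3N=C(c4ccc(C)s4)CC3c3ccc(F)cc3)n2)cc1` gives > 500 ug/mL, which is a limit of the assay and not a number. Compound 1 `Fc1ccc(C2CC(c3ccc(Cl)s3)=NN2c2nc(-c3ccc(Cl)cc3)cs2)cc1` gives > 500 ug/mL, also a limit. Compound 3 `Fc1ccc(C2CC(c3ccc(Cl)s3)=NN2c2nc(-c3ccc(C(F)(F)F)cc3)cs2)cc1` gives > 500 ug/mL, again a limit. Among the compounds with values here, the whole series so far therefore comes down to the limit of > 500 ug/mL in this assay, at which 3 of the 3 values shown sit, and compound 2 has no exact place within it.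

Compound 4 `Cc1ccc(C2=NN(c3nc(-c4ccccc4)cs3)C(c3ccc(F)cc3)C2)s1` differs from compound 2 by hydrogen in place of methyl on an aromatic carbon, which turns 4-methylphenyl into phenyl. Within the data shown here, the one measured step that bears on this is a step that the two limits leave unreadable from compound 1 to compound 3, trifluoromethyl in place of chloro on an aromatic carbon, and it offers no size to carry over. No shift beyond the scatter is therefore expected in this assay, and no direction can be given. The expected change is a step that the limit leaves unreadable from compound 2 to compound 4. Compound 4 is estimated at 550 ug/mL, with an expected range of 300 ug/mL to 1000 ug/mL, and it will probably again be reported only as a limit.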

Compound 4, half-maximal inhibitory concentration: > 500 ug/mL
Compound 4 ended at the assay's limit; the forecaster's own chance of this, stated with the estimate: 85%; the middle value lies beyond the limit too.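

The step from compound 2 to compound 4 cannot be read, because both values are limits of this assay and not numbers, and the whole series now sits at one such limit: the limit of > 500 ug/mL in this assay, at which 4 of the 4 values shown sit.

The compounds shown leave open whether removing either methyl or exchanging chloro for trifluoromethyl changes cytotoxicity at all, and where each compound's true value lies.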